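A few compounds are considered here, and "the series" means these few. Any claim that something is new, unique, unknown or untested is made for them only; others in the source may bear on it.

Compound 1 `Cc1c(C(=O)N/N=C\c2cccc(F)c2O)oc2cccc(O)c12` and compound 2 `Cc1c(C(=O)N/N=C\c2ccc(C(F)(F)F)cc2)oc2cccc(O)c12` share one core and differ only in the aromatic ring attached to the carbon that carries a double bond to nitrogen. In a functional assay on PC-3 cells (Homo sapiens) for inhibition (a higher number here means a weaker inhibitor, a lower number a stronger inhibitor), compound 1 gives 12700 nM, the only number measured so far among these compounds. Of compound 2 this assay reports no number but a limit, >= 40000 nM; this is the limit of >= 40000 nM in this assay, at which 1 of the 2 values shown sits. Compound 3 `Cc1c(C(=O)N/N=C\c2cc(F)ccc2O)oc2cccc(O)c12` has not yet been measured. It differs from compound 1 in one place: 5-fluoro-2-hydroxyphenyl in place of 3-fluoro-2-hydroxyphenyl on a carbon with a double bond to nitrogen. For the measured compounds named here, no pair of measured compounds shows such a change, so its effect cannot be read from a measured step. The expected step is a 1.1-fold lower number from compound 1 to compound 3 (0.02 log units; within the scatter), within the usual scatter and in no firm direction. On that basis compound 3 is estimated at 12000 nM, with a range from 4000 nM to 36000 nM.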

Compound 3, half-maximal inhibitory concentration: 3170 nM
The estimate for compound 3 lay 3.8-fold (0.58 log units) above the measured number; the whole stated range lies above it.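

In this assay, 5-fluoro-2-hydroxyphenyl in place of 3-fluoro-2-hydroxyphenyl gives a 4.0-fold lower number from compound 1 to compound 3 (0.60 log units; beyond the scatter) and so moves the result beyond the usual scatter. The two groups hold the same atoms, joined differently, so on this carbon with a double bond to nitrogen, the arrangement of the ring matters and not only which atoms it carries. Nothing measured here explains why this arrangement gives the lower number.

Whether the lower number depends on fluorine itself stays open, since no compound shown carries a chlorine atom, a methoxy group or an amine in its place. On these data alone, the role of the hydroxy group also stays open, since compound 2, whose ring lacks it and carries trifluoromethyl instead of fluorine, gives >= 40000 nM as a limit and not a number.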